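Removing a Methyl from the Ring Amine in Two Series

This account rests on a few compounds, and the source may have more. Where it says the series, first, only, none or still open, it means among the compounds named here.

Compound 2 `CN1CCN(c2nc(-n3ccc4ccccc43)c3ccccc3n2)CC1` and compound 1 `c1ccc2c(c1)ccn2-c1nc(N2CCNCC2)nc2ccccc12` share one core and differ only by hydrogen in place of methyl on an amine nitrogen in a ring. In a functional assay on DU-145 cells (Homo sapiens) for antiproliferative activity, read by MTT assay (on this read-out higher numbers stand for weaker inhibition and lower numbers for stronger inhibition), compound 2 gives 20.8 ug/mL, while compound 1 gives 12.5 ug/mL, so that a 1.7-fold lower number from compound 2 to compound 1 (0.22 log units; within the scatter). Compound 3 `COc1cc(OC)c(-c2nc(N3CCN(C)CC3)nc3ccccc23)c(OC)c1` carries the same methylated ring amine on a different core; the difference between the two cores is not broken down here. In this assay compound 3 gives 50 ug/mL, the highest of the three numbers and beyond the scatter from both compound 2 and compound 1. Compound 4 `COc1cc(OC)c(-c2nc(N3CCNCC3)nc3ccccc23)c(OC)c1` is the unmeasured partner of compound 3, differing by hydrogen in place of methyl on an amine nitrogen in a ring, the same change at the same place as between compound 2 and compound 1. That earlier step was a 1.7-fold lower number from compound 2 to compound 1 (0.22 log units; within the scatter). Resting on that measured step, for compound 4 a similarly small step a 1.4-fold lower number from compound 3 to compound 4 (0.15 log units; within the scatter) is expected. Compound 4 is therefore estimated at 35 ug/mL in this assay, most likely between 15 ug/mL and 80 ug/mL.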

Compound 4, half-maximal inhibitory concentration: 50 ug/mL
Beside the measured number, compound 4's estimate is 1.4-fold (0.15 log units) below it; the measured number falls inside the stated range.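

Replacing 4-methylpiperazin-1-yl with piperazin-1-yl on the core of compound 3 gives, in this assay, no change at the digits printed from compound 3 to compound 4 (within the scatter). The same change on the two cores gives steps that cannot be told apart: the same change on two cores in this assay, a 1.7-fold lower number (0.22 log units; within the scatter) from compound 2 to compound 1 and no change at the digits printed (within the scatter) from compound 3 to compound 4, 1.7-fold (0.22 log units) apart, within the scatter of two such steps. So a step too small to read carries over between these two cores, but since both steps lie within the scatter, neither shows that removing the methyl matters, and two cores do not make a rule for the series.

The compounds shown leave open how a larger group on the ring amine nitrogen, such as an ethyl or an acetyl group, would read in this test. They also leave open whether the step stays this small on a third core.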